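Ring contraction at the amide tail of compound 1

This account rests on a few compounds, and the source may have more. Where it says the series, first, only, none or still open, it means among the compounds named here.

The study covers a set of benzimidazole-like compounds examined for cytotoxicity. In an ADME assay on MDBK cells (Bos taurus) for cytotoxicity, read by MTT assay, with a stated time of 96 h (on this read-out lower numbers stand for higher toxicity in this test and higher numbers for lower toxicity in this test), compound 1 `Cn1c(-c2ccc(NC(=O)CN3CCCCC3)cc2)nc2cc(C(F)(F)F)ccc21` gives 100000 nM, the highest of the three numbers measured. Compound 3 `O=[N+]([O-])c1ccc(-c2nc3cc(C(F)(F)F)ccc3[nH]2)c([N+](=O)[O-])c1` comes nearest with 16000 nM, a gap that lies beyond the usual scatter, while compound 2 `COc1ccc(-c2nc3cc(Cl)c(Cl)cc3[nH]2)cc1` stands furthest away at 2500 nM, also beyond the scatter. Among the measured compounds shown here, no pair of these three differs in only one place, so no single step is computed between them.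

Compound 4 `Cn1c(-c2ccc(NC(=O)CN3CCCC3)cc2)nc2cc(C(F)(F)F)ccc21` has not yet been measured in this assay. It differs from compound 1 in one place: pyrrolidin-1-yl in place of piperidin-1-yl on a saturated chain carbon bound to a carbonyl carbon. Both rings carry no donor and one acceptor, and the change sits far from the shared core. For the measured compounds named here, with no comparable step among the measured compounds, the expectation for the step from compound 1 to compound 4 is none beyond the scatter, so the step is estimated as a 1.1-fold lower number from compound 1 to compound 4 (0.05 log units; within the scatter). Compound 4 is therefore expected to give about 90000 nM, within a range from 40000 nM to 200000 nM.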

Compound 4, half-maximal cytotoxic concentration: 65000 nM
Compound 4: the middle estimate sits 1.4-fold (0.14 log units) above what was measured; low and high end bracket the measured number.
By their numbers in this assay, from the lowest: compound 2; then compound 3; then compounds 4 and 1 (each within the scatter of the next).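

Among the compounds shown here, the step at the amide tail is the first comparison in the set that changes only one place. In this assay it reads a 1.5-fold lower number from compound 1 to compound 4 (0.19 log units; within the scatter) and so pyrrolidin-1-yl and piperidin-1-yl on a saturated chain carbon bound to a carbonyl carbon cannot be told apart on this read-out. This holds for this one pair only, and no data given here bear on why the two rings read alike.

The compounds shown leave open whether the position stays as quiet with a ring holding a second hetero atom, such as morpholin-4-yl, or with an open-chain amine, such as dimethylamino. They also leave open what a carboxylic acid would do at this place, or a larger ring such as azepan-1-yl.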